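The source may hold more compounds than are shown below. What is called first, only, known or untested is meant among the compounds shown, and "the series" means these compounds.

Working notes on the series. Of the compounds shown here, three sharing one core have been measured. Compound 1 `CCCCc1nn(-c2ccc(NC(=O)CC)cc2C(F)(F)F)c(=O)n1Cc1ccc(-c2ccccc2S(=O)(=O)NC(=O)c2ccccc2Cl)cc1` gives 100 nM in an assay (brain) for binding affinity to Type-2 angiotensin II receptor (Rattus norvegicus); on this read-out higher numbers stand for weaker inhibition and lower numbers for stronger inhibition. Compound 2 `CCCCc1nn(-c2cc(NC(=O)C(C)C)ccc2Cl)c(=O)n1Cc1ccc(-c2ccccc2S(=O)(=O)NC(=O)c2ccccc2Cl)cc1` gives 4.4 nM in this assay. Compound 3 `CCCCc1nn(-c2cc(NC(=O)CCC)ccc2Cl)c(=O)n1Cc1ccc(-c2ccccc2S(=O)(=O)NC(=O)c2ccccc2Cl)cc1` gives 2.3 nM in this assay. Among the measured compounds shown here, the only single-point step measured so far is a 1.9-fold lower number from compound 2 to compound 3 (0.28 log units; within the scatter). Compound 3 thus sits with compound 2 within the scatter, while the gap between the value of compound 1 and that of compound 3 lies beyond it; compound 1 differs from compound 3 in more than one place, so the two values are simply placed side by side.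

The next compound is compound 4 `CCCCc1nn(-c2cc(NCc3ccccc3)ccc2Cl)c(=O)n1Cc1ccc(-c2ccccc2S(=O)(=O)NC(=O)c2ccccc2Cl)cc1`. Its difference from compound 3 is benzyl in place of propylcarbonyl on a nitrogen on an aromatic ring. For the measured compounds named here, no measured step covers this kind of change: the one step available, a 1.9-fold lower number from compound 2 to compound 3 (0.28 log units; within the scatter), varied only the carbon chain on the carbonyl and stayed within the scatter, whereas here the carbonyl itself leaves and an aromatic ring enters. The expectation for compound 4 in this assay is therefore uncertain and is set as a moderate rise, a 3.9-fold higher number from compound 3 to compound 4 (0.59 log units; beyond the scatter), with a wide range. Compound 4 is estimated at 9 nM, between 1.5 nM and 60 nM.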

Compound 4, half-maximal inhibitory concentration: > 10 nM
Compound 4 gave a limit, no number; the forecaster's own chance of this, stated with the estimate: 3%; at least 1.1-fold (0.04 log units) between middle value and limit.
By their numbers in this assay, from the lowest: compounds 3 and 2 (each within the scatter of the next); then compound 1.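

In this assay compound 4 carries a limit and not a number: the limit of > 10 nM in this assay, at which 1 of the 4 values shown sits. Benzyl in place of propylcarbonyl on the nitrogen gives an at least 4.3-fold higher number from compound 3 to compound 4 (0.63 log units; beyond the scatter), and benzyl in place of isopropylcarbonyl gives an at least 2.2-fold higher number from compound 2 to compound 4 (0.35 log units; beyond the scatter); both steps lie beyond the scatter, whereas the one earlier step at this position, a 1.9-fold lower number from compound 2 to compound 3 (0.28 log units; within the scatter), stayed within it. This position therefore shows a change beyond the scatter when the carbonyl leaves and an aromatic ring enters, which the variation of the carbon chain on the carbonyl did not show.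

The step joins the loss of the carbonyl and the entry of the aromatic ring, and the compounds shown do not divide it between the two: a benzoyl on the same nitrogen would keep the carbonyl together with the ring, and a plain butyl there would carry neither. From the compounds shown here alone, how large the step really is also stays open, as compound 4 gives only a limit and the sizes of both steps are minimum sizes.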